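A few compounds are considered here, and "the series" means these few. Any claim that something is new, unique, unknown or untested is made for them only; others in the source may bear on it.

Compound 1 `O=C1CSC(=O)N1C[C@H]1CN(c2ccc(-n3cc(-c4ccccn4)cn3)c(F)c2)C(=O)O1` is built on a shared core carrying a 2,4-dioxo-1,3-thiazolidin-3-yl group on a saturated chain carbon bound to a saturated ring carbon. Within the data shown here, in a physicochemical assay for lipophilicity, read by HPLC, measured as octanol-water partition (on this read-out higher numbers stand for higher lipophilicity and lower numbers for lower lipophilicity), compound 1 gives 2.18, the lowest of the three values so far. Compound 2 `O=C(OC[C@H]1CN(c2ccc(-n3cc(-c4ccccn4)cn3)c(F)c2)C(=O)O1)c1ccccc1` gives 4.21 in this assay, and compound 3 `O=C1O[C@@H](CSc2cccs2)CN1c1ccc(-n2cc(-c3ccccn3)cn2)c(F)c1` gives 4.29. Both replace that group at the same place: a number 2.03 log units higher from compound 1 to compound 2 (beyond the scatter), and a number 2.11 log units higher from compound 1 to compound 3 (beyond the scatter), while the two replacements sit close together, a number 0.08 log units higher from compound 2 to compound 3 (within the scatter).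

Compound 4 `CS(=O)(=O)NC[C@H]1CN(c2ccc(-n3cc(-c4ccccn4)cn3)c(F)c2)C(=O)O1` changes compound 1 at the same place: methanesulfonamido in place of 2,4-dioxo-1,3-thiazolidin-3-yl on a saturated chain carbon bound to a saturated ring carbon. The two measured steps both bring in a ring and a large rise; the entering methanesulfonamido group has no ring and adds a hydrogen-bond donor, so those steps give only loose guidance. The expected step is therefore small and, if anything, downward: a number 0.38 log units lower from compound 1 to compound 4 (beyond the scatter). Compound 4 is estimated at 1.8, between 1.2 and 2.4.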

Compound 4, partition coefficient: 1.38
For compound 4 the middle estimate is 0.42 log units above the measured one; measured number inside the range.
By their numbers in this assay, from the lowest: compound 4; then compound 1; then compounds 2 and 3 (each within the scatter of the next).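

At this place, on a saturated chain carbon bound to a saturated ring carbon, a replacement for the 2,4-dioxo-1,3-thiazolidin-3-yl group can also lower the number in this assay and not only raise it, as methanesulfonamido does (a number 0.80 log units lower from compound 1 to compound 4 (beyond the scatter)). Measured against the two other replacements, the same group gives far larger drops (a number 2.83 log units lower from compound 2 to compound 4 (beyond the scatter) and a number 2.91 log units lower from compound 3 to compound 4 (beyond the scatter)), so the four groups shown now span a wide range at this one place. Nothing measured here explains these shifts.

Methanesulfonamido differs from the group it replaces by having no ring and by carrying a hydrogen-bond donor, and compounds 1 and 4 cannot separate these two differences. Going by these compounds, whether an amine or a carboxylic acid at this place would read lower still remains open.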